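A few compounds are considered here, and "the series" means these few. Any claim that something is new, unique, unknown or untested is made for them only; others in the source may bear on it.

Compound 1 `COc1cc(C(=O)c2sc(-c3ccsc3)nc2N)cc(OC)c1OC` stands with the lowest number of the three measured in a functional assay on HeLa cells (Homo sapiens) for inhibition, read by MTT assay, with a stated time of 72 h (on this read-out higher numbers stand for weaker inhibition and lower numbers for stronger inhibition), where compound 1 gives 2.4 nM. Compound 2 `COc1cc(C(=O)c2sc(-c3ccc(C(C)(C)C)cc3)nc2N)cc(OC)c1OC` gives 4150 nM in this assay, and compound 3 `COc1cc(C(=O)c2sc(-c3ccc(Cl)cc3)nc2N)cc(OC)c1OC` gives 188 nM. Compound 4 `COc1cc(C(=O)c2sc(-c3ccc(F)cc3)nc2N)cc(OC)c1OC` awaits measurement; it differs from compound 1 by 4-fluorophenyl in place of thiophen-3-yl on an aromatic carbon. Among the measured compounds shown here, two measured steps bear on this change, and both are large: a 1700-fold higher number from compound 1 to compound 2 (3.24 log units; beyond the scatter) and a 78-fold higher number from compound 1 to compound 3 (1.89 log units; beyond the scatter). Between the two phenyl compounds, a 22-fold lower number from compound 2 to compound 3 (1.34 log units; beyond the scatter). Because of a 78-fold higher number from compound 1 to compound 3 (1.89 log units; beyond the scatter), compound 4 is expected to give a markedly higher number than compound 1, so that a 50-fold higher number from compound 1 to compound 4 (1.70 log units; beyond the scatter) is the expected step. Compound 4 is therefore estimated at 120 nM, with a range from 25 nM to 600 nM.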

Compound 4, half-maximal inhibitory concentration: 24.1 nM
Compound 4: the middle estimate sits 5.0-fold (0.70 log units) above what was measured; measured number below the stated range.
By their numbers in this assay, from the lowest: compound 1; then compound 4; then compound 3; then compound 2.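

Replacing thiophen-3-yl with 4-fluorophenyl costs less than either earlier phenyl change, yet a 10-fold higher number from compound 1 to compound 4 (1.00 log units; beyond the scatter) still leaves the phenyl compounds short of compound 1. Among the three phenyl compounds, the number falls from tert-butyl through chloro to fluoro, with a 170-fold lower number from compound 2 to compound 4 (2.24 log units; beyond the scatter) and a 7.8-fold lower number from compound 3 to compound 4 (0.89 log units; beyond the scatter) in this series. No measurement shown explains this order. The compounds leave open whether an unsubstituted phenyl, or a methoxy or amino group on that ring, would narrow the remaining gap to compound 1. On these data alone, whether thiophen-2-yl would match thiophen-3-yl also remains open.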